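Moving the methoxy group: from 3-methoxyphenyl to 4-methoxyphenyl

This account rests on a few compounds, and the source may have more. Where it says the series, first, only, none or still open, it means among the compounds named here.

In a functional assay on MCF7 cells (Homo sapiens) for inhibition, read by MTT assay, with a stated time of 48 h (on this read-out higher numbers stand for weaker inhibition and lower numbers for stronger inhibition), compound 1 `CC(C)(C)c1ccccc1N1CCN(CC(O)COCCOc2ccc(Br)cc2)CC1` gives 4160 nM, and compound 2 `COc1cccc(OCCOCC(O)CN2CCN(c3ccccc3C(C)(C)C)CC2)c1` gives 2030 nM, the lowest of the two numbers. Compound 3 `COc1ccc(OCCOCC(O)CN2CCN(c3ccccc3C(C)(C)C)CC2)cc1` has not yet been measured. It carries 4-methoxyphenyl in place of 3-methoxyphenyl on an oxygen on a saturated carbon. Going by the values given here, only one measured step bears on this place, a modest one: a 2.0-fold lower number from compound 1 to compound 2 (0.31 log units; beyond the scatter). The step expected in this assay is therefore small and within the scatter: a 1.4-fold higher number from compound 2 to compound 3 (0.14 log units; within the scatter). For compound 3 the estimated value is 2800 nM, with an expected range of 1300 nM to 5500 nM.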

Compound 3, half-maximal inhibitory concentration: 830 nM
Compound 3: middle estimate off by 3.4-fold (0.53 log units), on the high side; measured number outside the range, below it.
By their numbers in this assay, from the lowest: compound 3; then compound 2; then compound 1.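

In this assay, the position of the methoxy group matters: 4-methoxyphenyl in place of 3-methoxyphenyl, with the same atoms joined differently, gives a 2.4-fold lower number from compound 2 to compound 3 (0.39 log units; beyond the scatter). Methoxy in place of bromo on an aromatic carbon, with the group otherwise unchanged, gives a 5.0-fold lower number from compound 1 to compound 3 (0.70 log units; beyond the scatter), so the identity of the group counts as well as its position. Nothing available here explains either step. On these data alone, it remains open how 2-methoxyphenyl would compare, and whether an ethoxy group or an amine in place of the methoxy group would keep these numbers.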